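Swapping Ethoxy for Amino on a Carbonyl Carbon

The source may hold more compounds than are shown below. What is called first, only, known or untested is meant among the compounds shown, and "the series" means these compounds.

In a functional assay on the whole organism for inhibition, with Cavia porcellus as the target (a lower number here means that less compound is needed, a higher number that more compound is needed for the effect), compound 1 (`CCOC(=O)Cc1cn2cc(Br)nc(Br)c2n1`) gives 21 nM and compound 2 (`CCOC(=O)c1c(C)nc2cnccn12`) gives 19 nM. Compound 3 (`CCOC(=O)c1cn2c(Br)cncc2n1`) gives 52 nM, the highest of the three numbers and beyond the scatter from both others, so it needs the most compound for the effect.

Compound 4 (`NC(=O)c1cn2c(Br)cncc2n1`) keeps the core of compound 3 and changes one group, with amino in place of ethoxy on a carbonyl carbon, so that ethoxycarbonyl becomes carbamoyl (amino in place of ethoxy on a carbonyl carbon). For the measured compounds named here, all three measured compounds carry ethoxycarbonyl and none carries carbamoyl, so no measured pair shows what this exchange does in this assay. The forecast is therefore a cautious judgement with a wide margin. A moderate rise beyond the scatter, meaning that more compound is needed, is expected, with an estimated step of a 2.9-fold higher number from compound 3 to compound 4 (0.46 log units; beyond the scatter). For compound 4 the estimated value is 150 nM, with an expected range from 35 nM to 700 nM.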

Compound 4, concentration for half-maximal effect: 38 nM
The estimate for compound 4 lay 3.9-fold (0.60 log units) above the measured number; the measured number falls inside the stated range.
By their numbers in this assay, from the lowest: compounds 2, 1, 4 and 3 (each within the scatter of the next, the first and the last beyond it).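

For the compounds shown here, compound 3 and compound 4 form the first pair here that differs in only one place, so they give the first direct reading of a change at this carbonyl carbon. In this assay, putting amino in place of ethoxy turns ethoxycarbonyl into carbamoyl and gives a small step (a 1.4-fold lower number from compound 3 to compound 4 (0.14 log units; within the scatter)), so on this core the two groups cannot be told apart, even though the 3 heavy atoms of ethoxy give way to the 1 heavy atom of amino. Nothing measured here bears on the reason for this result.

Going by these compounds, whether a methylamino group, a dimethylamino group or a carboxylic acid on this carbonyl carbon would also stay within the scatter remains open. On these data alone, it is also open whether the same exchange would read the same way on the cores of compound 1 and compound 2.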